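The source may report more compounds than this note shows. Statements on the series, on what has been measured and on what is new or still open speak of the compounds shown alone.

Measured compounds:
- compound 1, `CC(=O)c1ccc2c(c1)N(C1=CCCC1=O)CC(C)(C)S2`, gives 88% in a functional assay on aorta (Rattus norvegicus, strain Wistar); a higher number here means a larger maximal response, a lower number a smaller maximal response
- compound 2, `CC(=O)Nc1ccc2c(c1)N(C1=CCCC1=O)CC(C)(C)S2`, gives 97% in this assay
- compound 3, `CC1CN(C2=CCCC2=O)c2cc(C(F)(F)F)ccc2S1`, gives 94% in this assay

Compound 1 has the lowest of the three numbers, but the gaps to compound 3 and to compound 2 are both within the usual scatter of this assay, so the three measured compounds cannot be told apart on these values.

Compound 4, `CC1(C)CN(C2=CCCC2=O)c2cc(C(F)(F)F)ccc2S1`, has not yet been measured. It differs from compound 1 in one place: trifluoromethyl in place of acetyl on an aromatic carbon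

Among the measured compounds shown here, only one measured step touches the same place on the shared core: a number 9 percentage points higher from compound 1 to compound 2 (within the scatter). That step swapped the acetyl for an acetamido group and left the maximal response essentially unchanged. Compound 3 carries a trifluoromethyl group at that same place and gives 94%, again close to the other two. Nothing seen so far suggests that a change at this position moves the maximal response beyond the scatter.

Compound 4 is therefore expected to give about 92% in this assay, with a likely range of 80% to 102%. The estimated step is a number 4 percentage points higher from compound 1 to compound 4 (within the scatter), which is expected to lie within the scatter.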

Compound 4, largest response reached (Emax), in percent of the reference or control that the assay uses: 92%
Estimate against measurement, compound 4: no gap at the digits printed; the range from low to high includes it.
By their numbers in this assay, from the lowest: compounds 1, 4, 3 and 2 (each within the scatter of the next).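

In this assay, trifluoromethyl can now be compared directly with the other two groups on the same core, which compound 3 could not do because it also differs on a saturated ring carbon: replacing acetyl gives (a number 4 percentage points higher from compound 1 to compound 4 (within the scatter)), and replacing acetamido gives (a number 5 percentage points lower from compound 2 to compound 4 (within the scatter)). Trifluoromethyl has no hydrogen-bond acceptor, whereas acetyl has one, yet this exchange on the aromatic carbon leaves no difference that can be told from the scatter. Compound 4 also opens a second place to the comparison, and methyl in place of hydrogen on the saturated ring carbon gives (a number 2 percentage points lower from compound 3 to compound 4 (within the scatter)), so this change also leaves the maximal response indistinguishable from that of compound 3.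

No measured information is at hand to explain why these responses stay so close.

The compounds shown leave open whether an amine, a carboxylic acid or a longer chain on this aromatic carbon would move the maximal response beyond the scatter. These values also describe only the largest response reached, so they leave open how much of each compound is needed to reach it.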